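Methylpyrazole to imidazole: a step expected within scatter

The compounds below may be only part of what the source reports. "The series", "measured", "known", "first", "only" and "open" are said of these compounds alone.

Compound 3 `Cc1cc(C)c(NC(=O)N(Cc2ccc(-c3ccn(C)n3)cc2)C2CCCCCC2)c(C)c1` carries a 1-methyl-1H-pyrazol-3-yl group on its aromatic ring. In a functional assay on a cell-free system (plasma) with sterol O-acyltransferase, Soat (Rattus norvegicus) as the target (on this read-out higher numbers stand for an effect only at larger amounts of compound and lower numbers for an effect already at smaller amounts), compound 3 gives < 1 mg/kg, which is a limit of the assay rather than a number. Compound 2 `Cc1cc(C)c(NC(=O)N(Cc2ccc(-c3cccnc3)cc2)C2CCCCCC2)c(C)c1` gives 0.58 mg/kg in this assay. Compound 1 `Cc1cc(C)c(NC(=O)N(Cc2ccc(-c3n[nH]c(C)n3)cc2)C2CCCCCC2)c(C)c1` gives > 1 mg/kg in this assay, also a limit. The steps of a number no higher from compound 1 to compound 3 (the limit leaves the size open) and a step that the limit leaves unreadable from compound 2 to compound 3 therefore leave the standing of compound 3 open, while an at least 1.7-fold lower number from compound 1 to compound 2 (0.23 log units; that floor lies within the scatter) shows a modest change. Compound 4 `Cc1cc(C)c(NC(=O)N(Cc2ccc(-n3ccnc3)cc2)C2CCCCCC2)c(C)c1` differs from compound 3 by 1H-imidazol-1-yl in place of 1-methyl-1H-pyrazol-3-yl on an aromatic carbon. The leaving and entering groups are alike in ring type and size, and the step that the limit leaves unreadable from compound 3 to compound 4 is expected to stay within the scatter. Compound 4 is estimated at 0.6 mg/kg, with a range from 0.2 mg/kg to 2 mg/kg.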

Compound 4, dose for half-maximal effect: > 1 mg/kg
Compound 4 gave a limit, no number; the forecaster's own chance of this, stated with the estimate: 35%; at least 1.6-fold (0.22 log units) between middle value and limit.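

Putting 1H-imidazol-1-yl in place of pyridin-3-yl, para to a large group, gives an at least 1.7-fold higher number from compound 2 to compound 4 (0.23 log units; that floor lies within the scatter). Compound 4 stands at a limit of the assay, not a number: the limit of > 1 mg/kg in this assay, at which 2 of the 4 values shown sit. Putting 1H-imidazol-1-yl in place of 1-methyl-1H-pyrazol-3-yl gives a number no lower from compound 3 to compound 4 (the limit leaves the size open). Within the data shown here, the step from compound 1 to compound 4 cannot be read, so the result shows only that this ring, attached through nitrogen, brings no sign of a gain at this place. From the compounds shown here alone, how far the true value of compound 4 lies from its limit stays open. Also open, going by these compounds, is how a carboxylic acid or a dimethylamino group would fare at this place.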